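Cytotoxicity of a Piperazine Series: From Chloro to Bromo

This account rests on a few compounds, and the source may have more. Where it says the series, first, only, none or still open, it means among the compounds named here.

Measured so far:
compound 1 `O=C(CN1CCN(C(=O)c2ccc(Cl)cc2)CC1)N1CCN(CCCc2c[nH]c3ccccc23)CC1`: 98200 nM
compound 2 `O=C(CN1CCN(C(=O)c2ccc(Cl)cc2)CC1)N1CCN(CCCc2c[nH]c3ccc(F)cc23)CC1`: 44500 nM

In an ADME assay on HEK293 cells (Homo sapiens) for cytotoxicity, read by MTT assay, with a stated time of 72 h (on this read-out higher numbers stand for weaker inhibition and lower numbers for stronger inhibition), compound 2 gives the lowest of the two numbers, with compound 1 giving a higher one by a 2.2-fold lower number from compound 1 to compound 2 (0.34 log units; beyond the scatter). Compound 3 `O=C(CN1CCN(C(=O)c2ccccc2Br)CC1)N1CCN(CCCc2c[nH]c3ccc(F)cc23)CC1` differs from compound 2 by 2-bromophenyl in place of 4-chlorophenyl on a carbonyl carbon. For the measured compounds named here, no measured step concerns this part of the shared core, so the only known step, a 2.2-fold lower number from compound 1 to compound 2 (0.34 log units; beyond the scatter), does not bear on it. Therefore no step beyond the usual scatter is expected in this assay, though the range is kept wide. Compound 3 is estimated at 45000 nM, between 15000 nM and 135000 nM, an expected step of a 1.0-fold higher number from compound 2 to compound 3 (0.00 log units; within the scatter).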

Compound 3, half-maximal inhibitory concentration: 77100 nM
For compound 3 the middle estimate is 1.7-fold (0.23 log units) below the measured one; measured number inside the range.
By their numbers in this assay, from the lowest: compounds 2, 3 and 1 (each within the scatter of the next, the first and the last beyond it).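

For the compounds shown here, compound 3 gives the only reading at this position: in this assay, replacing 4-chlorophenyl with 2-bromophenyl on the carbonyl carbon gives a 1.7-fold higher number from compound 2 to compound 3 (0.24 log units; within the scatter), so this assay does not separate the two compounds. This single exchange therefore produces no step beyond the scatter. No measurement shown offers an explanation for this result.

Both the halogen and its place on the ring changed at once, so 4-bromophenyl would be needed to tell those two changes apart. From the compounds shown here alone, how an amine or a carboxylic acid on this phenyl ring would read remains open.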